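The source may hold more compounds than are shown below. What is called first, only, known or untested is meant among the compounds shown, and "the series" means these compounds.

In an ADME assay on HUVEC cells (Homo sapiens) for inhibition, read by CCK-8 assay, with a stated time of 24 h, in the presence of a further agent that is not named here (on this read-out higher numbers stand for weaker inhibition and lower numbers for stronger inhibition), compound 1 `O=C1Nc2ccccc2/C1=C/c1ccc(-c2cn(-c3ccccc3F)nn2)cc1` gives 19300 nM, compound 2 `O=C1Nc2ccccc2/C1=C/c1ccc(-c2cn(-c3ccc(Cl)cc3)nn2)cc1` gives 18200 nM and compound 3 `N#Cc1ccccc1-n1cc(-c2ccc(/C=C3\C(=O)Nc4ccccc43)cc2)nn1` gives 19700 nM. Compound 1 thus stands level with both others, since all three values lie within the scatter of one another. This is seen in a 1.1-fold lower number from compound 1 to compound 2 (0.03 log units; within the scatter), in a 1.0-fold higher number from compound 1 to compound 3 (0.01 log units; within the scatter) and in a 1.1-fold higher number from compound 2 to compound 3 (0.03 log units; within the scatter). Compound 4 `O=C1Nc2ccc(F)cc2/C1=C/c1ccc(-c2cn(-c3ccccc3F)nn2)cc1` keeps the 2-fluorophenyl group of compound 1 and alters the core instead: fluoro in place of hydrogen on an aromatic carbon of a six-membered aromatic ring of carbon only, part of a fused or bridged system of two rings. Among the measured compounds shown here, no measured step touches that ring, as all of them change the aryl group on an aromatic nitrogen, so they bear on this change only indirectly. The expectation therefore rests on compound 1 at 19300 nM, with no direction indicated by the data. The expected change is a 1.1-fold lower number from compound 1 to compound 4 (0.03 log units; within the scatter), which is no step beyond the scatter. Compound 4 is expected at 18000 nM, within an estimated range of 9000 nM to 32000 nM.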

Compound 4, half-maximal inhibitory concentration: 14400 nM
The estimate for compound 4 lay 1.3-fold (0.10 log units) above the measured number; the range from low to high includes it.
By their numbers in this assay, from the lowest: compounds 4, 2, 1 and 3 (each within the scatter of the next).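

The fluoro on an aromatic carbon of the six-membered aromatic ring of carbon only, meta to a fused ring and para to a fused ring, is the first change shown in the shared core rather than in the aryl group on the aromatic nitrogen, and in this assay it gives a 1.3-fold lower number from compound 1 to compound 4 (0.13 log units; within the scatter). This position therefore takes a fluoro in place of hydrogen without a step beyond the scatter, so the core, like the aryl group, has not yet shown a change that separates two compounds. Nothing available explains this result.

As far as these compounds go, it remains open whether another group at this place, such as an amine, a methoxy group or a carboxylic acid, would move the number beyond the scatter. From the compounds shown here alone, it is also open whether the fluoro would behave the same way alongside the 4-chlorophenyl group of compound 2 or the 2-cyanophenyl group of compound 3.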